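Dropping one chloro from compound 2

The source may hold more compounds than are shown below. What is called first, only, known or untested is meant among the compounds shown, and "the series" means these compounds.

In a functional assay on SW-620 cells (Homo sapiens) (a lower number here means a stronger inhibitor of growth, a higher number a weaker inhibitor of growth), compound 1 `O=S(=O)(/C=C/c1ccc(Cl)c(Cl)c1)Cc1ccc(Nc2ncnc3ccccc23)cc1` gives 41000 nM while compound 2 `O=S(=O)(/C=C/c1ccc(Cl)c(Cl)c1)Cc1ccc(Nc2ncnc3ccc(Br)cc23)cc1` gives 5000 nM as the lower of the two numbers. Compound 3 `O=S(=O)(/C=C/c1ccc(Cl)cc1)Cc1ccc(Nc2ncnc3ccc(Br)cc23)cc1` differs from compound 2 by hydrogen in place of chloro on an aromatic carbon with hydrogen in place of chloro on an aromatic carbon, turning 3,4-dichlorophenyl into 4-chlorophenyl. Going by the values given here, the only measured step is an 8.2-fold lower number from compound 1 to compound 2 (0.91 log units; beyond the scatter) and it is modest, with bromo in place of hydrogen, so no measured step bears directly on the chloro. The expected step is a 1.4-fold higher number from compound 2 to compound 3 (0.15 log units; within the scatter) and a slightly higher number, but none beyond the scatter. In this assay compound 3 is estimated at 7000 nM (expected range 2500 nM to 20000 nM).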

Compound 3, concentration for 50% growth inhibition: 45000 nM
Beside the measured number, compound 3's estimate is 6.4-fold (0.81 log units) below it; the whole stated range lies below it.
By their numbers in this assay, from the lowest: compound 2; then compounds 1 and 3 (each within the scatter of the next).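

In this assay, the chloro on this aromatic carbon, ortho to a chloro group, matters: taking it away, turning 3,4-dichlorophenyl into 4-chlorophenyl, gives a 9.0-fold higher number from compound 2 to compound 3 (0.95 log units; beyond the scatter) and so undoes the gain seen with bromo. Going by these compounds alone, a change on the 3,4-dichlorophenyl group, and not only one on the core, therefore moves the number beyond the scatter. Nothing available here accounts for this step.

On these data alone, whether a fluoro, methyl or methoxy group on this carbon would keep the number of compound 2 stays open. So does whether this chloro counts the same without the bromo.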